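Difluorophenyl in Place of Biphenyl on the Shared Core

The compounds below may be only part of what the source reports. "The series", "measured", "known", "first", "only" and "open" are said of these compounds alone.

Compound 1 `CC(C)[C@H](NC(=O)COc1cccc2ccccc12)C(=O)N[C@@H](CC(=O)O)C(=O)COc1ccc(-c2ccccc2)cc1` carries a 4-phenylphenyl group on an oxygen on a saturated carbon. For the measured compounds named here, in a functional assay on Jurkat cells (Homo sapiens) (on this read-out higher numbers stand for weaker inhibition and lower numbers for stronger inhibition), compound 1 gives 87900 nM, and this is the only number among the three values shown. Compound 2 `CC(C)[C@H](NC(=O)COc1cccc2ccccc12)C(=O)N[C@@H](CC(=O)O)C(=O)COc1ccccc1F` reaches only the limit > 100000 nM in this assay. Compound 3 `CC(C)[C@H](NC(=O)COc1cccc2ccccc12)C(=O)N[C@@H](CC(=O)O)C(=O)COc1cccc(F)c1` likewise reaches only the limit > 100000 nM in this assay. The step of an at least 1.1-fold higher number from compound 1 to compound 2 (0.05 log units; that floor lies within the scatter) and the step of an at least 1.1-fold higher number from compound 1 to compound 3 (0.05 log units; that floor lies within the scatter) both end at the limit of > 100000 nM in this assay, at which 2 of the 3 values shown sit. The step that the two limits leave unreadable from compound 2 to compound 3 cannot be read from the two limits. Compound 4 `CC(C)[C@H](NC(=O)COc1cccc2ccccc12)C(=O)N[C@@H](CC(=O)O)C(=O)COc1cc(F)ccc1F` has not yet been measured; it differs from compound 1 by 2,5-difluorophenyl in place of 4-phenylphenyl on an oxygen on a saturated carbon. Both measured exchanges of 4-phenylphenyl for a fluorophenyl gave a higher number, so the step of a 1.7-fold higher number from compound 1 to compound 4 (0.23 log units; within the scatter) is expected to point the same way, with a good chance of ending at a limit. Compound 4 is therefore estimated at 150000 nM, within a range from 70000 nM to 400000 nM.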

Compound 4, half-maximal inhibitory concentration: > 100000 nM
Compound 4 ended at the assay's limit (the forecaster's own chance of this, stated with the estimate: 75%); the middle value lies beyond the limit too.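

For the compounds shown here, the exchange of 4-phenylphenyl for 2,5-difluorophenyl gives an at least 1.1-fold higher number from compound 1 to compound 4 (0.05 log units; that floor lies within the scatter) in this assay, and the first two-fluorine group at this place behaves no differently from the single-fluorine groups on the printed values. The value of compound 4, > 100000 nM, is a limit and not a number, so a second fluoro on the ring did not bring a readable value back. Going by these compounds alone, the steps of fluoro in place of hydrogen from compound 2 and from compound 3 to compound 4 cannot be read, and compound 1 remains the only one with a number: the limit of > 100000 nM in this assay, at which 3 of the 4 values shown sit.

As far as these compounds go, how far compound 2, compound 3 and compound 4 lie beyond that limit stays unknown. Also open, from the compounds shown here alone, is whether a naphthyl or 4-phenoxyphenyl group on this oxygen, or a phenyl ring carrying an amine or a carboxylic acid, would give a readable number.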